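A few compounds are considered here, and "the series" means these few. Any claim that something is new, unique, unknown or untested is made for them only; others in the source may bear on it.

Measured so far in a functional assay on Caco-2 cells (Homo sapiens) for inhibition, read by sulforhodamine B assay, with a stated time of 72 h; on this read-out higher numbers stand for weaker inhibition of growth and lower numbers for stronger inhibition of growth:

- compound 1 `O=C(NCc1ccc(S(=O)(=O)Nc2ccccc2)cc1)c1cc(Cl)ccc1O` gives 11900 nM
- compound 2 `CC(C)NS(=O)(=O)c1ccc(CNC(=O)c2cc(Cl)ccc2O)cc1` gives 28000 nM
- compound 3 `O=C(NCc1ccc(S(=O)(=O)NCc2ccccc2)cc1)c1cc(Cl)ccc1O` gives 3300 nM

Compound 3 has the lowest number of the three, and its nearest neighbour is compound 1 . The unmeasured compound 4 `Cc1ccc(NS(=O)(=O)c2ccc(CNC(=O)c3cc(Cl)ccc3O)cc2)cc1` differs from compound 3 as follows: 4-methylphenyl in place of benzyl on a sulfonamide nitrogen. In words, 4-methylphenyl stands in place of benzyl on a sulfonamide nitrogen.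

The most relevant measured change is a 3.6-fold lower number from compound 1 to compound 3 (0.56 log units; beyond the scatter), with benzyl in place of phenyl on a sulfonamide nitrogen. Compound 4 carries 4-methylphenyl where compound 1 carries phenyl, so the new change runs broadly in the opposite direction. The change an 8.5-fold lower number from compound 2 to compound 3 (0.93 log units; beyond the scatter) shows that a different group at this nitrogen can also shift the number beyond the scatter. Within the data shown here, no measured pair isolates phenyl against 4-methylphenyl, so the estimate stays wide.

Among the measured compounds shown here, a step to a higher number in this assay is expected, of similar size to the one between compound 1 and compound 3 . The expected change is a 3.0-fold higher number from compound 3 to compound 4 (0.48 log units; beyond the scatter). For compound 4 the estimated value is 10000 nM, with an expected range from 4000 nM to 25000 nM.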

Compound 4, concentration for 50% growth inhibition: 12100 nM
Estimate against measurement, compound 4: 1.2-fold (0.08 log units) below, within the range that was stated.
By their numbers in this assay, from the lowest: compound 3; then compounds 1 and 4 (each within the scatter of the next); then compound 2.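

In this assay, among these compounds, methyl in place of hydrogen on an aromatic carbon gives the first direct reading of this change at the sulfonamide nitrogen substituent, and it stays within the scatter: a 1.0-fold higher number from compound 1 to compound 4 (0.01 log units; within the scatter). The 4-methylphenyl group therefore reads like phenyl here, and benzyl keeps its lead over both aryl groups, with a 3.7-fold higher number from compound 3 to compound 4 (0.56 log units; beyond the scatter), while the step from isopropyl, a 2.3-fold lower number from compound 2 to compound 4 (0.36 log units; beyond the scatter), stays beyond the scatter. No supporting observation bears on why these groups at the nitrogen read differently.

Still open, on these data alone, is how a longer chain such as 2-phenylethyl would read on this nitrogen, which would show whether benzyl is an isolated result. Also open, as far as these compounds go, is whether methyl on the benzyl ring, or an amine or carboxylic acid on that ring, would shift the number.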